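The source may hold more compounds than are shown below. What is called first, only, known or untested is meant among the compounds shown, and "the series" means these compounds.

Working notes on an assay on CHO cells for displacement of a labelled ligand from prostaglandin E2 receptor EP4 subtype (Mus musculus), read by scintillation counting; on this read-out higher numbers stand for weaker inhibition and lower numbers for stronger inhibition. Compound 1 `O=C(O)/C=C/c1ccc(COc2ccccc2)cc1OCCc1ccc2ccccc2c1` gives 2600 nM. Compound 2 `O=C(O)/C=C/c1ccc(OCc2ccccc2)cc1OCCc1ccc2ccccc2c1` returns only > 10000 nM, a limit of the assay rather than a number. Within the data shown here, the single measured step, an at least 3.8-fold higher number from compound 1 to compound 2 (0.58 log units; beyond the scatter), concerns a different part of the shared core and rests on (the limit of > 10000 nM in this assay, at which 1 of the 3 values shown sits). Compound 3 `O=C(O)C#Cc1ccc(Cn2cccn2)cc1OCCc1ccc2ccccc2c1` gives 2900 nM; its number and that of compound 1 lie within the usual scatter of each other, so no order between them is claimed. Compound 4 `O=C(O)CCCc1ccc(Cn2cccn2)cc1OCCc1ccc2ccccc2c1` differs from compound 3 by 3-carboxypropyl in place of 2-carboxyethynyl on an aromatic carbon. Among the measured compounds shown here, no measured step touches this acid-bearing chain, so the step from compound 1 to compound 2 gives no direct guide. The shift is expected to stay near the scatter, a 1.2-fold higher number from compound 3 to compound 4 (0.08 log units; within the scatter). Compound 4 is estimated at 3500 nM, between 1200 nM and 12000 nM.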

Compound 4, inhibition constant: 1400 nM
For compound 4 the middle estimate is 2.5-fold (0.40 log units) above the measured one; measured number inside the range.
By their numbers in this assay, from the lowest: compounds 4, 1 and 3 (each within the scatter of the next, the first and the last beyond it). At a limit, above all of these: compound 2.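

In this assay, the acid-bearing chain para to the (1H-pyrazol-1-yl)methyl group now has a measured step of its own: a 2.1-fold lower number from compound 3 to compound 4 (0.32 log units; beyond the scatter). The triple bond is therefore not needed to keep this level of inhibition, and the modest gain goes with the saturated 3-carboxypropyl chain. The change alters both chain length and the triple bond, and nothing measured gives a cause for the step. Open, from the compounds shown here alone, is whether 2-carboxyethyl, with the shorter saturated chain, would separate these two changes. Also open, going by these compounds, is whether a tetrazole or an amide could stand in for the carboxylic acid.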